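A few compounds are considered here, and "the series" means these few. Any claim that something is new, unique, unknown or untested is made for them only; others in the source may bear on it.

Measured so far in a functional assay on HeLa cells (Homo sapiens) for inhibition, read by MTT assay, with a stated time of 72 h; on this read-out higher numbers stand for weaker inhibition and lower numbers for stronger inhibition:
- compound 1 `COc1ccc(/C=C/C(=O)c2c(OC)cc(O)c(CC=C(C)C)c2O)cc1`: > 50000 nM (a limit)
- compound 2 `COc1ccc(/C=C/C(=O)c2c(O)cc(O)cc2OC)cc1`: 47700 nM

Going by the values given here, compound 2 gives 47700 nM, the only actual number so far. For compound 1, the result of > 50000 nM is a limit and not a number (the limit of > 50000 nM in this assay, at which 1 of the 2 values shown sits).

The next compound is compound 3 `COc1cc(O)cc(O)c1C(=O)/C=C/c1ccc(C)cc1`, with methyl in place of methoxy on an aromatic carbon of a six-membered aromatic ring of carbon only, para to a large group (methyl in place of methoxy on an aromatic carbon).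

Among the compounds with values here, only one measured step exists, an at least 1.0-fold lower number from compound 1 to compound 2 (0.02 log units; that floor lies within the scatter). It is hydrogen in place of 3-methylbut-2-en-1-yl on an aromatic carbon, so it is a different change from the one at hand and bears on it only loosely. Within the data shown here, no measured step covers methyl in place of methoxy, and the data give no direction for this change in this assay.

The step of a 1.1-fold lower number from compound 2 to compound 3 (0.03 log units; within the scatter) is therefore expected to stay within the scatter, with no direction favoured. Compound 3 is estimated at 45000 nM, with an expected range of 20000 nM to 90000 nM. A result reported only as a limit is also a real expectation for this compound.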

Compound 3, half-maximal inhibitory concentration: > 50000 nM
Compound 3: only a limit was reported; the forecaster's own chance of this, stated with the estimate: 45%; middle value at least 1.1-fold (0.04 log units) away from the limit.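

In this assay compound 3 gives > 50000 nM, which is a limit and not a number. Methyl in place of methoxy, on an aromatic carbon para to a large group, is the only change at this position with a measured result, and it reads as an at least 1.0-fold higher number from compound 2 to compound 3 (0.02 log units; that floor lies within the scatter), so only a floor is known and the true size of the step could be within the scatter or well beyond it. The earlier compounds gave no information on this position; the methyl compound now shows no sign of a lower number than compound 2, and the series gathers at a single ceiling: the limit of > 50000 nM in this assay, at which 2 of the 3 values shown sit.

With only methoxy and methyl shown at this position and a single actual number in the series, it stays open whether an amine, a carboxylic acid or a longer alkoxy chain there would bring a result clear of the limit. As far as these compounds go, it is also open whether 3-methylbut-2-en-1-yl on the core of compound 3 would give a real number, and thus whether the two changes act independently.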